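The source may hold more compounds than are shown below. What is called first, only, known or untested is meant among the compounds shown, and "the series" means these compounds.

Compound 1 `CC1=CSC(OCC2CCCCC2)(c2ccccc2)c2noc(=O)n21`: 870 nM
Compound 2 `COc1ccc(C2(OCC3CCCCC3)SC=C(C)n3c2noc3=O)cc1`: 660 nM
Compound 3 `COc1ccccc1C1(O)SC=C(C)n2c1noc2=O`: 930 nM

These values come from a functional assay (Left cardiac atrium, Cavia porcellus), with a stated time of 30 min; on this read-out higher numbers stand for an effect only at larger amounts of compound and lower numbers for an effect already at smaller amounts. Compound 3, at 930 nM, lies within the usual scatter of both compound 1 and compound 2, so the three cannot be ranked.

Compound 4 `COc1ccccc1C1(OCC2CCCCC2)SC=C(C)n2c1noc2=O` differs from compound 3 in one place: cyclohexylmethyl in place of hydrogen on an oxygen on a saturated carbon. Put simply, hydroxy becomes cyclohexylmethoxy. Going by the values given here, no measured step shows this change directly. Among the compounds with values here, the one measured step, a 1.3-fold lower number from compound 1 to compound 2 (0.12 log units; within the scatter), concerns a methoxy on an aromatic carbon and stays within the scatter. It offers only indirect support, as both of its compounds already carry cyclohexylmethoxy. Compound 1 at 870 nM and compound 2 at 660 nM both sit close to compound 3 at 930 nM. The expected result in this assay is therefore no change beyond the scatter, with an estimated step of a 1.3-fold lower number from compound 3 to compound 4 (0.12 log units; within the scatter). Compound 4 is estimated at 700 nM, with an expected range of 300 nM to 1600 nM.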

Compound 4, half-maximal effective concentration: 480 nM
Beside the measured number, compound 4's estimate is 1.5-fold (0.16 log units) above it; the measured number falls inside the stated range.
By their numbers in this assay, from the lowest: compounds 4, 2, 1 and 3 (each within the scatter of the next).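

Replacing hydroxy with cyclohexylmethoxy on the saturated ring carbon gives a 1.9-fold lower number from compound 3 to compound 4 (0.29 log units; within the scatter) in this assay and stays within the scatter, so this position accepts the much larger group without a clear change in the read-out. With cyclohexylmethoxy in place, 2-methoxyphenyl in place of 4-methoxyphenyl gives a 1.4-fold lower number from compound 2 to compound 4 (0.14 log units; within the scatter) and methoxy in place of hydrogen on an aromatic carbon gives a 1.8-fold lower number from compound 1 to compound 4 (0.26 log units; within the scatter) and both steps stay within the scatter, so neither the presence of this methoxy nor its place separates these compounds. The data shown offer no explanation for these small steps.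

The compounds shown leave open whether a different group on this oxygen, such as a plain methyl or a chain ending in an amine, would move the number beyond the scatter. They also leave open whether a carboxylic acid at that spot would do so.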